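Moving the ring nitrogen: from compound 2 to compound 3

The compounds below may be only part of what the source reports. "The series", "measured", "known", "first", "only" and "open" are said of these compounds alone.

Of the compounds shown here, two have been measured in an assay on isolated protein for binding affinity to high affinity nerve growth factor receptor (Homo sapiens) (a lower number here means tighter binding, a higher number weaker binding), so far. Compound 1, `COc1ccc(-c2c[nH]c3ncc(-c4cncc(NS(=O)(=O)c5ccccc5)c4)cc23)cc1OC`, gives 145 nM in this assay. Compound 2, `Nc1cccc(-c2cnc3[nH]cc(-c4ccncc4)c3c2)c1`, gives 16 nM in this assay, which is the lower of the two numbers; the gap between them lies well beyond the usual scatter, so compound 2 is the tighter binder of the pair. The two differ in many places at once, so the values show only where each stands, not what any single change does.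

Compound 3, `Nc1cccc(-c2cnc3[nH]cc(-c4cccnc4)c3c2)c1`, has not yet been measured. It has the same atoms as compound 2 joined differently: pyridin-3-yl in place of pyridin-4-yl on an aromatic carbon. Going by the values given here, only the pyridyl ring is altered, and no measured pair shows what this change does here. A modest step is expected, if any, most likely toward a somewhat higher number and quite possibly within the scatter. The step from compound 2 to compound 3 is estimated as a 1.9-fold higher number from compound 2 to compound 3 (0.27 log units; within the scatter). Compound 3 is therefore expected to give about 30 nM in this assay, within a range of 8 nM to 120 nM.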

Compound 3, dissociation constant: 75 nM
Estimate against measurement, compound 3: 2.5-fold (0.40 log units) below, and the stated range covers the measured number.
By their numbers in this assay, from the lowest: compound 2; then compounds 3 and 1 (each within the scatter of the next).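

Going by these compounds alone, compound 2 and compound 3 form the first pair here that differs in one place only, so in this assay the effect of moving the nitrogen within the pyridyl ring can be read on its own: pyridin-3-yl in place of pyridin-4-yl brings a 4.7-fold higher number from compound 2 to compound 3 (0.67 log units; beyond the scatter) and so a real weakening of binding rather than noise. The two groups have the same atoms and the same counts of hydrogen-bond donors and acceptors, so this aromatic carbon, two ring bonds from the ring nitrogen of the shared core, responds to where the nitrogen sits in the attached ring, not only to which atoms are present. Nothing available here bears on why the number rises.

Going by these compounds, whether a nitrogen in this ring matters at all stays open, since a plain phenyl ring or pyridin-2-yl at the same carbon would be needed to tell, and these two pyridyl groups alone cannot settle it. On these data alone, whether the step keeps its size when the aminophenyl group on the other side of the core is replaced by another group also remains unknown.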